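Dropping a Methyl from the Aryl Ring in a Pyrimidine Series

This account rests on a few compounds, and the source may have more. Where it says the series, first, only, none or still open, it means among the compounds named here.

Of the compounds shown here, two have been measured in an assay on isolated protein for binding affinity to corticotropin-releasing factor receptor 1 (Rattus norvegicus); on this read-out higher numbers stand for weaker inhibition and lower numbers for stronger inhibition. Compound 1, `Cc1cc(C)nc(N(C)c2ccccc2I)n1`, carries an iodine on its phenyl ring and gives 3660 nM. Compound 2, `Cc1ccc(N(C)c2nc(C)cc(C)n2)c(Br)c1`, carries a bromine and a methyl on that ring; in this assay compound 2 gives 1100 nM. Of the two numbers, compound 2 stands lowest, and its gap to compound 1 lies beyond the usual scatter.

Compound 3, `Cc1cc(C)nc(N(C)c2ccccc2Br)n1`, has not yet been measured. It differs from compound 2 in one place: hydrogen in place of methyl on an aromatic carbon. Going by the values given here, no measured pair shows exactly this change, so the size of the step has to be judged from the two numbers available. Compound 1 shows that a phenyl ring bearing only a halogen can sit well above compound 2 in this assay, so a weakening step is expected for compound 3 going a 2.3-fold higher number from compound 2 to compound 3 (0.36 log units; beyond the scatter). For compound 3 in this assay the estimate is 2500 nM, expected to fall between 1000 nM and 6000 nM.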

Compound 3, inhibition constant: 5700 nM
Compound 3: middle estimate off by 2.3-fold (0.36 log units), on the low side, within the range that was stated.
By their numbers in this assay, from the lowest: compound 2; then compounds 1 and 3 (each within the scatter of the next).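

In this assay, the methyl on the aromatic carbon, which sits meta to a bromo group and para to a large group, clearly counts: putting hydrogen in its place gives a 5.2-fold higher number from compound 2 to compound 3 (0.71 log units; beyond the scatter), a step beyond the scatter and the first direct measure of this change in the series. On the ring without that methyl, bromo in place of iodo gives a 1.6-fold higher number from compound 1 to compound 3 (0.19 log units; within the scatter), which lies within the scatter, so these two halogens cannot be told apart in this setting. The data offer no measurement that would explain why the methyl matters to the binding number.

Going by these compounds alone, the series holds only this one methyl-to-hydrogen pair, and it carries bromo on the ring, so it remains open whether the step would be the same size with iodo there instead. On these data alone, it is also open whether the methyl is special or whether another group on the same carbon, such as an ethyl chain, a methoxy group or a chlorine, would give a similar number.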